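Replacing an allyl ether with a glycol chain

The source may hold more compounds than are shown below. What is called first, only, known or untested is meant among the compounds shown, and "the series" means these compounds.

The measured compounds:
compound 1, `O=C(O)COc1ccc(-c2coc3cc(OCC(=O)O)ccc3c2=O)cc1`, >> 9000 nM
compound 2, `O=C(O)CCCCCOc1ccc2c(=O)cc(-c3ccc(O)cc3)oc2c1`, 3500 nM
compound 3, `C=CCOc1ccc2c(=O)c(-c3ccc(O)cc3)coc2c1`, 180 nM

Of the compounds shown here, three sharing one core have been measured in an assay (Cricetulus griseus) for inhibition of aldehyde dehydrogenase, mitochondrial (Homo sapiens); a higher number here means a weaker inhibitor, a lower number a stronger inhibitor. For compound 1 the result is a limit of the assay, not a number: compound 1 gives >> 9000 nM, and (the limit of >> 9000 nM in this assay, at which 1 of the 3 values shown sits). Compound 2 gives 3500 nM in this assay. Compound 3 gives 180 nM and stands lowest of the two numbers; its nearest neighbour is compound 2, whose number is higher by a gap that lies beyond the usual scatter.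

Compound 4, `O=c1c(-c2ccc(O)cc2)coc2cc(OCCOCCOCCO)ccc12`, has not yet been measured. It differs from compound 3 in one place: (2-(2-hydroxyethoxy)ethoxy)methyl in place of vinyl on a saturated chain carbon bound to an oxygen on an aromatic ring. Among the measured compounds shown here, no single-change step between two measured compounds is available, so the size of this step can only be expected, not read off. Because compound 2, with its longer oxygen-linked chain, gives 3500 nM while compound 3 gives 180 nM, the author expects the step from the allyl ether to the longer, more oxygen-rich chain to raise the number, and by more than the scatter. Compound 4 is therefore estimated at 1000 nM, with a range from 300 nM to 4000 nM, which corresponds to an expected step of a 5.6-fold higher number from compound 3 to compound 4 (0.74 log units; beyond the scatter).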

Compound 4, half-maximal inhibitory concentration: 40 nM
Estimate against measurement, compound 4: 25-fold (1.40 log units) above; measured number below the stated range.
By their numbers in this assay, from the lowest: compound 4; then compound 3; then compound 2. At a limit, above all of these: compound 1.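

Among the compounds shown here, with this step, a single change at the saturated chain carbon bound to an oxygen on an aromatic ring can be read for the first time in this assay: allyl gives way to 2-(2-(2-hydroxyethoxy)ethoxy)ethyl, and the result is a 4.5-fold lower number from compound 3 to compound 4 (0.65 log units; beyond the scatter). The step shows that this position accepts a much larger group, with ether oxygens and a hydroxyl that the vinyl end of the allyl group lacks, and that the number falls rather than rises, a change beyond the scatter. Nothing measured here accounts for the direction of this step.

A single step cannot show whether the lower number goes with the length of the chain, its ether oxygens or its hydroxyl, since all three enter together. A plain hexyl chain, a chain of the same length capped as a methyl ether, a shorter 2-hydroxyethyl group or a chain ending in an amine would each separate these features, and the compounds shown leave open how any of them would behave at this position.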